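A few compounds are considered here, and "the series" means these few. Any claim that something is new, unique, unknown or untested is made for them only; others in the source may bear on it.

Measured so far:
compound 1, `CCCCC(CC)C(=O)Nc1ccc2ccn(Cc3ccc(C(=O)NS(=O)(=O)c4ccc(Cl)cc4)cc3OC)c2c1`, 7.8;
compound 2, `CCCCC(CC)C(=O)Nc1ccc2ccn(Cc3ccc(C(=O)C(C#N)S(=O)(=O)c4ccccc4)cc3OC)c2c1`, 8.1;
compound 3, `CCCCC(CC)C(=O)Nc1ccc2ccn(Cc3ccc(C(=O)NS(=O)(=O)c4ccc(OC)cc4)cc3OC)c2c1`, 7.4.

In a functional assay (trachea) for antagonist activity, with Cavia porcellus as the target (on this read-out higher numbers stand for higher potency (the scale is a negative logarithm) and lower numbers for lower potency), compound 3 stands lowest of the three numbers. Its nearest neighbour is compound 1, and a number 0.40 log units lower from compound 1 to compound 3 (beyond the scatter) is a modest step beyond the scatter; the gap to compound 2, a number 0.70 log units lower from compound 2 to compound 3 (beyond the scatter), is wider, also modest and beyond the scatter.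

Compound 4, `CCCCC(CC)C(=O)Nc1ccc2ccn(Cc3ccc(C(=O)NS(=O)(=O)c4ccc(C)cc4)cc3OC)c2c1`, differs from compound 3 in one place: methyl in place of methoxy on an aromatic carbon. The change sits on an aromatic carbon of a six-membered aromatic ring of carbon only, para to a large group.

Going by the values given here, only one measured step touches this position. From compound 1 to compound 3 the chloro was exchanged for methoxy, and a number 0.40 log units lower from compound 1 to compound 3 (beyond the scatter), which shows that the group at this carbon moves this assay by a modest amount. Among the compounds with values here, no measured pair compares methyl with either chloro or methoxy, so the direction for compound 4 rests on that single step alone. Taking methoxy out again is expected to recover part of that loss, and the step from compound 3 to compound 4 is estimated at a number 0.20 log units higher from compound 3 to compound 4 (within the scatter), within the scatter.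

Compound 4 is therefore expected to give about 7.6 in this assay, with a likely range from 7.2 to 8.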

Compound 4, negative logarithm of the antagonist equilibrium constant: 8.4
Compound 4: middle estimate off by 0.80 log units, on the low side, outside the stated range (above it).
By their numbers in this assay, from the lowest: compound 3; then compounds 1, 2 and 4 (each within the scatter of the next, the first and the last beyond it).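

In this assay the group on this aromatic carbon, para to a large group, counts for more than the single earlier step showed: methyl in place of methoxy gives a number 1.00 log units higher from compound 3 to compound 4 (beyond the scatter), the widest step yet among these compounds. Methyl does more than recover what methoxy lost, since methyl in place of chloro gives a number 0.60 log units higher from compound 1 to compound 4 (beyond the scatter), so the three groups at this carbon now read methoxy, chloro, methyl from the lowest number to the highest. With methyl here, the ((4-methylphenyl)sulfonyl)amino compound can no longer be told apart from the cyano(phenylsulfonyl)methyl compound, as a number 0.30 log units higher from compound 2 to compound 4 (within the scatter) shows.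

Nothing available explains why methyl stands above both chloro and methoxy at this carbon. As far as these compounds go, it remains open whether an ethyl group, a trifluoromethyl group or a plain hydrogen on this carbon would carry the number further or drop it back, and whether a methyl group would act the same way on the phenyl ring of compound 2.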